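Thiophene variants on a diphenylmethyl sulfoxide core: compound 4

A few compounds are considered here, and "the series" means these few. Any claim that something is new, unique, unknown or untested is made for them only; others in the source may bear on it.

Measured so far in an assay on HEK293 cells for inhibition of sodium-dependent dopamine transporter (Homo sapiens), read by scintillation counting, with stated times of 5 min and 1 min; a higher number here means a weaker inhibitor, a lower number a stronger inhibitor:
- compound 1, `[O-][S+](Cc1cc(Br)cs1)C(c1ccccc1)c1ccccc1`: 13700 nM
- compound 2, `Cc1nnc(C[S+]([O-])C(c2ccccc2)c2ccccc2)s1`: "not active" (no number reported)
- compound 3, `[O-][S+](Cc1ccc(Cl)s1)C(c1ccccc1)c1ccccc1`: 12800 nM

For the measured compounds named here, compound 3 holds the lowest of the two numbers in this assay, but its nearest neighbour is compound 1, and the only measured step, a 1.1-fold lower number from compound 1 to compound 3 (0.03 log units; within the scatter), lies within the scatter; the two cannot be ordered. Compound 2, with the shared core and a different five-membered ring, gave no number at all in this assay.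

Compound 4, `[O-][S+](Cc1ccsc1)C(c1ccccc1)c1ccccc1`, is not yet measured. It differs from compound 3 in one place: thiophen-3-yl in place of 5-chlorothiophen-2-yl on a saturated chain carbon bound to a sulfur. Going by the values given here, no measured step addresses this change directly. Among the compounds with values here, the one step that bears on it is the exchange of one halogenated thiophene for another between compound 1 and compound 3, which moved the number hardly at all. The step expected in this assay is therefore small, a 1.3-fold higher number from compound 3 to compound 4 (0.10 log units; within the scatter), in no firm direction. Compound 4 is estimated at 16000 nM, with a range from 6000 nM to 45000 nM.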

Compound 4, half-maximal inhibitory concentration: 3000 nM
Beside the measured number, compound 4's estimate is 5.3-fold (0.73 log units) above it; the whole stated range lies above it.
By their numbers in this assay, from the lowest: compound 4; then compounds 3 and 1 (each within the scatter of the next).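

In this assay, the choice of thiophene on a saturated chain carbon bound to a sulfur does change the number: thiophen-3-yl gives a 4.3-fold lower number from compound 3 to compound 4 (0.63 log units; beyond the scatter) and a 4.6-fold lower number from compound 1 to compound 4 (0.66 log units; beyond the scatter), whereas the exchange between the two halogenated thiophenes gave no order. Compound 4 therefore stands apart from compounds 1 and 3, which remain within the scatter of each other, and both new steps, though modest, lie beyond the scatter. Nothing available here accounts for these steps.

On these data alone, compound 4 differs from compounds 1 and 3 both in lacking a halogen and in being a thiophen-3-yl, so it remains open which of these matters; a plain thiophen-2-yl would separate them. Also open, as far as these compounds go, is how this position would take a thiophene bearing an amine or a carboxylic acid.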